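The source may report more compounds than this note shows. Statements on the series, on what has been measured and on what is new or still open speak of the compounds shown alone.

Of the compounds shown here, three built on one shared core have been tested in an assay on HL-60 cells for agonist activity at N-formyl peptide receptor 3 (Homo sapiens), read by calcium flux; on this read-out higher numbers stand for an effect only at larger amounts of compound and lower numbers for an effect already at smaller amounts. Compound 1 `COc1ccc(Cc2cc(-c3cccs3)nn(CC(=O)Nc3ccc(Br)cc3)c2=O)cc1` carries a thiophen-2-yl group. In this assay compound 1 gives > 50000 nM, which is a limit of the assay and not a number. Compound 2 `COc1ccc(Cc2cc(-c3ccc(OC)cc3)nn(CC(=O)Nc3ccc(Br)cc3)c2=O)cc1` has 4-methoxyphenyl in place of thiophen-2-yl on an aromatic carbon. In this assay compound 2 likewise reaches only a limit, > 50000 nM. Compound 3 `COc1ccc(Cc2cc(-c3ccc(C)cc3)nn(CC(=O)Nc3ccc(Br)cc3)c2=O)cc1` has 4-methylphenyl in that place. In this assay compound 3 again gives a limit, > 50000 nM. Because the limit of > 50000 nM in this assay, at which 3 of the 3 values shown sit, covers every value shown, the steps a step that the two limits leave unreadable from compound 1 to compound 2, a step that the two limits leave unreadable from compound 1 to compound 3 and a step that the two limits leave unreadable from compound 2 to compound 3 cannot be sized, and compound 3 stands at the same limit as the other two. Compound 4 `COc1ccc(Cc2cc(Cc3ccccc3)nn(CC(=O)Nc3ccc(Br)cc3)c2=O)cc1` has not yet been measured; it differs from compound 3 by benzyl in place of 4-methylphenyl on an aromatic carbon. Within the data shown here, no measured step bears on a change of this kind, so neither direction nor size of step can be read from the data. Compound 4 is therefore expected to give about 50000 nM, with a range from 5000 nM to 100000 nM. This estimate corresponds to an expected step of a number no higher from compound 3 to compound 4 (the limit leaves the size open).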

Compound 4, half-maximal effective concentration: > 50000 nM
Compound 4 was reported as a limit; the forecaster's own chance of this, stated with the estimate: 80%; the middle value lies on the limit itself.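

Among these compounds, compound 4 also sits at a limit of the assay, so no step from compound 1, compound 2 or compound 3 to compound 4 can be read, because all four compounds share that limit: the limit of > 50000 nM in this assay, at which 4 of the 4 values shown sit. The compounds shown leave open whether any group at this place on the shared core gives a measurable effect in this assay at all.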